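Ehrlich cell cytotoxicity notes: carbamate in place of acyl azide

The source may report more compounds than this note shows. Statements on the series, on what has been measured and on what is new or still open speak of the compounds shown alone.

Compound 1 `Cc1c(C(=O)N=[N+]=[N-])[n+]([O-])c2cc(Cl)ccc2[n+]1[O-]` is the reference point of the series. In a functional assay on Ehrlich cells (Mus musculus) for cytotoxicity, read by trypan blue exclusion, with a stated time of 2 h, tested at 10 ug/mL (on this read-out lower numbers stand for a stronger effect and higher numbers for a weaker effect at the one concentration tested), compound 1 gives 88.3%, the highest of the three numbers recorded, so it stands as the weakest of the measured compounds. Compound 2 `COc1ccc2c(c1)[n+]([O-])c(C(=O)N=[N+]=[N-])c(C)[n+]2[O-]` gives 58.3% in this assay, and compound 3 `COc1ccc(NC(=O)Nc2c(C)[n+]([O-])c3ccc(Cl)cc3[n+]2[O-])cc1` gives 50.2%; both numbers lie beyond the scatter below that of compound 1.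

Among the compounds with values here, the one step measured between compounds differing in a single place is a number 30 percentage points lower from compound 1 to compound 2 (beyond the scatter), a methoxy in place of chloro on an aromatic carbon. Within the data shown here, no step is recorded between compound 1 and compound 3, which differ in more than one place; their values alone show compound 3 at the lower number.

Compound 4 `Cc1c(NC(=O)OC(C)C)[n+]([O-])c2cc(Cl)ccc2[n+]1[O-]` differs from compound 1 by a group of 7 heavy atoms (4 carbon, 1 nitrogen, 2 oxygen; no ring) in place of a group of 5 heavy atoms (1 carbon, 3 nitrogen, 1 oxygen; no ring), on an aromatic carbon. Among the measured compounds shown here, no measured step exchanges the acyl-type group at this position, so nothing bears directly on the change; the methoxy-for-chloro step concerns another place. Given that both measured departures from compound 1 gave lower numbers, a modest drop is expected but with wide uncertainty, a number 20.3 percentage points lower from compound 1 to compound 4 (beyond the scatter). For compound 4 in this assay the estimate is 68%, within a range from 45% to 92%.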

Compound 4, a percentage reported as activity, at one concentration (the size of the read-out at that concentration, not a potency): 97.3%
Compound 4: middle estimate off by 29.3 percentage points, on the low side; measured number above the stated range.
By their numbers in this assay, from the lowest: compounds 3 and 2 (each within the scatter of the next); then compounds 1 and 4 (each within the scatter of the next).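

In this assay, within the data shown here, this is the first exchange at the position on the aromatic carbon next to the ring nitrogen, and (isopropoxycarbonyl)amino in place of the acyl azide gives a number 9 percentage points higher from compound 1 to compound 4 (within the scatter). On the chloro-bearing core, then, this position accepts a carbamate for the acyl azide with no change in the read-out beyond the scatter at the one concentration tested, whereas the methoxy-for-chloro exchange at the other place gives a number 30 percentage points lower from compound 1 to compound 2 (beyond the scatter). No measurement on hand accounts for the absence of a shift at this position.

Going by these compounds, it remains open whether the same exchange would read alike on the methoxy-bearing core of compound 2, where the acyl azide starts from a lower number. On these data alone, it also remains open whether a free amine or a carboxylic acid at this position, or a longer chain in place of the isopropyl part of the carbamate, would move the number beyond the scatter from that of compound 1.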